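The source may hold more compounds than are shown below. What is called first, only, known or untested is meant among the compounds shown, and "the series" means these compounds.

Measured compounds:
Compound 1 `CC1(C)S[C@@H]2C/C(=C\C(=O)c3ccccc3)C(=O)N2[C@H]1C(=O)OC(c1ccccc1)c1ccccc1` gives > 100000 nM in a functional assay on A-375 cells (Homo sapiens) for cytotoxicity, read by MTT assay, with a stated time of 48 h; on this read-out higher numbers stand for weaker inhibition and lower numbers for stronger inhibition — a limit of the assay.
Compound 2 `CC1(C)[C@H](C(=O)OC(c2ccccc2)c2ccccc2)N2C(=O)/C(=C/C(=O)c3ccc([N+](=O)[O-])cc3)[C@H]2[S+]1[O-]` gives 48200 nM in this assay.
Compound 3 `CC1(C)S[C@@H]2/C(=C\C(=O)c3ccc(F)cc3)C(=O)N2[C@H]1C(=O)OC(c1ccccc1)c1ccccc1` gives 17800 nM in this assay.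

Compound 2 stands at the highest of the two numbers reported, with compound 3 as its nearest neighbour, whose value lies lower by a gap beyond the scatter. Compound 1 is reported only as a limit and gives no number to set beside them.

Compound 4 `CC1(C)[C@H](C(=O)OC(c2ccccc2)c2ccccc2)N2C(=O)/C(=C/C(=O)c3ccccc3)[C@H]2[S+]1[O-]` differs from compound 2 by one change: hydrogen in place of nitro on an aromatic carbon. Among the measured compounds shown here, no step between measured compounds matches this change, so its size can only be guessed. Compound 1, which carries the same unsubstituted phenyl on a different core, is reported only as a limit. Compound 4 is therefore expected to weaken rather than strengthen, with a step of a 1.5-fold higher number from compound 2 to compound 4 (0.16 log units; within the scatter) from compound 2 to compound 4. Compound 4 is expected to give about 70000 nM in this assay, within a range from 25000 nM to 200000 nM.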

Compound 4, half-maximal inhibitory concentration: 4500 nM
The estimate for compound 4 lay 16-fold (1.19 log units) above the measured number; the whole stated range lies above it.
By their numbers in this assay, from the lowest: compound 4; then compound 3; then compound 2. At a limit, above all of these: compound 1.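

Among the compounds shown here, the change to hydrogen gives an 11-fold lower number from compound 2 to compound 4 (1.03 log units; beyond the scatter) in this assay and is the only step here that changes one place while the rest of the structure stays fixed. It shows that the group on this aromatic carbon, para to a large group, matters on this core, with phenyl giving the lower number and 4-nitrophenyl the higher one. No measurement shown accounts for the size of this step.

Only nitro and hydrogen can be compared at this place on this core, since compound 3 carries its fluorine on a structure that differs from compound 4 in more than one place. The compounds shown therefore leave open whether a methoxy group, an amine or a carboxylic acid at this position would give a number nearer to that of compound 4 or compound 2.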